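The source may report more compounds than this note shows. Statements on the series, on what has been measured and on what is new or still open speak of the compounds shown alone.

Compound 1 (`COc1ccc(/C=C\c2cc(OC)c(OC)c(OC)c2)cc1OCc1ccc(CNC(C)(C)C(=O)O)cc1`) and compound 2 (`COc1ccc(/C=C\c2cc(OC)c(OC)c(OC)c2)cc1OCc1ccc(CN[C@H](C(=O)O)[C@H](C)O)cc1`) share one core and differ only in the group on the amine nitrogen. In a functional assay on HepG2 cells (Homo sapiens) for antiproliferative activity, read by CCK-8 assay, with a stated time of 48 h (a higher number here means a weaker inhibitor, a lower number a stronger inhibitor), compound 1 gives 6500 nM as its result. Compound 2 gives > 10000 nM and this is a limit of the assay, not a number. Compound 3 (`COc1ccc(/C=C\c2cc(OC)c(OC)c(OC)c2)cc1OCc1ccc(CN2CC[C@H](C(=O)O)C2)cc1`) changes the same side chain again, with 3-carboxypyrrolidin-1-yl in place of (1-carboxy-2-hydroxypropyl)amino on a saturated chain carbon bound to an aromatic carbon, and the count runs 3-carboxypyrrolidin-1-yl in place of (1-carboxy-2-hydroxypropyl)amino on a saturated chain carbon bound to an aromatic carbon in full. For the measured compounds named here, only one measured step bears on this change, and it is an at least 1.5-fold higher number from compound 1 to compound 2 (0.18 log units; that floor lies within the scatter) as seen in the same side chain. On that slim evidence, no step beyond the scatter is expected in this assay here. The expected step is an at least 1.1-fold lower number from compound 2 to compound 3 (0.04 log units; that floor lies within the scatter) as an estimate. For compound 3 the estimated value is 9000 nM within a range of 3500 nM to 20000 nM in this assay.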

Compound 3, half-maximal inhibitory concentration: 6400 nM
For compound 3 the middle estimate is 1.4-fold (0.15 log units) above the measured one; the range from low to high includes it.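

In this assay the change from the open (1-carboxy-1-methylethyl)amino side chain to 3-carboxypyrrolidin-1-yl gives a 1.0-fold lower number from compound 1 to compound 3 (0.01 log units; within the scatter), so at this place, on a saturated chain carbon bound to an aromatic carbon, a five-membered ring holding the amine nitrogen reads the same as the open chain. Compound 2 gives > 10000 nM, which is a limit of the assay and not a number. Measured against that limit, the change shows an at least 1.5-fold lower number from compound 2 to compound 3 (0.19 log units; that floor lies within the scatter), so even with compound 3 now measured, no step at this place has been shown to lie beyond the scatter.

From the compounds shown here alone, whether a side chain with no carboxylic acid, such as a plain dimethylamino group or a methyl ester, would give a different value stays open. The true distance between compound 2 and compound 3 also stays unread, because compound 2 rests on a limit: the limit of > 10000 nM in this assay, at which 1 of the 3 values shown sits.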